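A few compounds are considered here, and "the series" means these few. Any claim that something is new, unique, unknown or untested is made for them only; others in the source may bear on it.

Compound 1 `COC(=O)c1c(F)cccc1OC(=O)COc1cc(O)c2c(=O)cc(-c3ccccc3)oc2c1`, compound 2 `COC(=O)c1c(Br)cc(Br)cc1OC(=O)COc1cc(O)c2c(=O)cc(-c3ccccc3)oc2c1` and compound 3 `COC(=O)c1c(Br)cccc1OC(=O)COc1cc(O)c2c(=O)cc(-c3ccccc3)oc2c1` share one core and differ only in the halogens on one aromatic ring. In a functional assay on cells (T-cell, Mus musculus, strain BALB/c) for inhibition, read by MTT assay, with a stated time of 72 h (a lower number here means a stronger inhibitor, a higher number a weaker inhibitor), compound 1 gives 40300 nM, compound 2 gives 45700 nM and compound 3 gives 41700 nM; compound 3 stands in the middle of the three, and all three lie within the scatter of one another. Compound 4 `COC(=O)c1c(Cl)cccc1OC(=O)COc1cc(O)c2c(=O)cc(-c3ccccc3)oc2c1` carries chloro in place of bromo on an aromatic carbon. The two halogen swaps already measured moved nothing: a 1.0-fold higher number from compound 1 to compound 3 (0.01 log units; within the scatter) and a 1.1-fold lower number from compound 2 to compound 3 (0.04 log units; within the scatter). For compound 4 the expected step is therefore a 1.0-fold higher number from compound 3 to compound 4 (0.00 log units; within the scatter), no change beyond the scatter in either direction. Compound 4 is estimated at 42000 nM, with a likely range from 21000 nM to 84000 nM.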

Compound 4, half-maximal inhibitory concentration: 38900 nM
Beside the measured number, compound 4's estimate is 1.1-fold (0.03 log units) above it; measured number inside the range.
By their numbers in this assay, from the lowest: compounds 4, 1, 3 and 2 (each within the scatter of the next).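

In this assay, chloro at this carbon, ortho to a methoxycarbonyl group, matches the other halogens: chloro in place of bromo gives (a 1.1-fold lower number from compound 3 to compound 4 (0.03 log units; within the scatter)), and chloro in place of fluoro gives (a 1.0-fold lower number from compound 1 to compound 4 (0.02 log units; within the scatter)). Fluoro, chloro and bromo at this position therefore all read the same within the scatter, so the halogen series shows no trend here. Nothing available explains this flat result.

Open, from the compounds shown here alone, is whether a group other than a halogen at this carbon, such as an amine, a carboxylic acid or a longer chain, would move the number beyond the scatter.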